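Methoxy for dimethylamino on the shared core: Vero cytotoxicity

This account rests on a few compounds, and the source may have more. Where it says the series, first, only, none or still open, it means among the compounds named here.

Compound 3 `CCn1cc(C(=O)N2N=C(c3cc4ccccc4o3)CC2c2ccc(N(C)C)cc2)c(=O)c2ccc(C)nc21` carries a dimethylamino group on its pendant phenyl ring. In an ADME assay on Vero cells (Chlorocebus sabaeus) for cytotoxicity, read by MTT assay, with a stated time of 72 h (a lower number here means a stronger inhibitor, a higher number a weaker inhibitor), compound 3 gives > 206000 nM, which is a limit of the assay and not a number. Compound 1 `O=C(O)c1ccccc1C1CC(c2cc3ccccc3o2)=NN1C(=O)c1ccncc1` in this assay gives > 170000 nM, again only a limit. Compound 2 `O=C(c1ccncc1)N1N=C(c2cc3ccccc3o2)CC1c1cccc([N+](=O)[O-])c1` in this assay gives > 240000 nM, also a limit. For the measured compounds named here, the one step between compounds that differ in a single place, a step that the two limits leave unreadable from compound 1 to compound 2, therefore cannot be read. All three measured values stop at a limit: the limit of > 170000 nM in this assay, at which 1 of the 3 values shown sits, the limit of > 206000 nM in this assay, at which 1 of the 3 values shown sits, and (the limit of > 240000 nM in this assay, at which 1 of the 3 values shown sits). Nothing among them shows a readable change in this assay.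

Compound 4 `CCn1cc(C(=O)N2N=C(c3cc4ccccc4o3)CC2c2ccc(OC)cc2)c(=O)c2ccc(C)nc21` differs from compound 3 by methoxy in place of dimethylamino on an aromatic carbon. Going by the values given here, no measured pair follows this particular change, and the only measured step is unreadable, so there is no ground for expecting compound 4 to move in either direction beyond the scatter. The step from compound 3 to compound 4, a step that the limit leaves unreadable from compound 3 to compound 4, is therefore expected to be none beyond the scatter, and compound 4 is most likely to return only a limit. For compound 4 in this assay the estimated value is 250000 nM, with a range from 150000 nM to 450000 nM.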

Compound 4, half-maximal inhibitory concentration: > 156000 nM
Compound 4: only a limit was reported; the forecaster's own chance of this, stated with the estimate: 85%; the middle value does not contradict the limit.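

In this assay compound 4 gives > 156000 nM, which is a limit of the assay and not a number. Compound 3 also stands only at a limit, so the step between compound 3 and compound 4 cannot be read. The compounds shown leave open at what concentration any of them would reach half-maximal inhibition in this assay, and so whether methoxy in place of dimethylamino changes that concentration at all.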